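The source may report more compounds than this note shows. Statements on the series, on what has been measured and on what is new or still open speak of the compounds shown alone.

Working notes on the series in a functional assay on MCF7 cells (Homo sapiens) for cytotoxicity, read by MTT assay, with a stated time of 24 h; on this read-out higher numbers stand for weaker inhibition and lower numbers for stronger inhibition. Compound 1 (`CCNc1cc(-c2ccc(NC(=O)Nc3ccc(OC)cc3)cc2C)ccn1`) gives 9950 nM, compound 2 (`CCNc1cc(-c2ccc(NC(=O)Nc3ccccc3Cl)cc2C)ccn1`) gives 8350 nM and compound 3 (`CCNc1cc(-c2ccc(NC(=O)Nc3ccc(OC)cc3)cc2OC)ccn1`) gives 17500 nM. Methoxy in place of methyl on an aromatic carbon gave a 1.8-fold higher number from compound 1 to compound 3 (0.25 log units; within the scatter). The number for compound 3 is beyond the scatter only against that for compound 2.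

Compound 4 (`CCNc1cc(-c2ccc(NC(=O)Nc3ccccc3Cl)cc2OC)ccn1`) differs from compound 3 by 2-chlorophenyl in place of 4-methoxyphenyl on an amide-type nitrogen. The same exchange, 2-chlorophenyl in place of 4-methoxyphenyl on an amide-type nitrogen, was measured once, as a 1.2-fold lower number from compound 1 to compound 2 (0.08 log units; within the scatter). No change beyond the scatter is therefore expected in this assay. The expected step is a 1.2-fold lower number from compound 3 to compound 4 (0.08 log units; within the scatter). Compound 4 is estimated at 14700 nM, with an expected range of 8500 nM to 25000 nM.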

Compound 4, half-maximal inhibitory concentration: 9940 nM
For compound 4 the middle estimate is 1.5-fold (0.17 log units) above the measured one; low and high end bracket the measured number.
By their numbers in this assay, from the lowest: compounds 2, 4, 1 and 3 (each within the scatter of the next, the first and the last beyond it).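

On the core of compound 3, 2-chlorophenyl in place of 4-methoxyphenyl on an amide-type nitrogen gives a 1.8-fold lower number from compound 3 to compound 4 (0.25 log units; within the scatter), so this exchange now stands on two cores with no step beyond the scatter: the same change on two cores in this assay, a 1.2-fold lower number (0.08 log units; within the scatter) from compound 1 to compound 2 and a 1.8-fold lower number (0.25 log units; within the scatter) from compound 3 to compound 4, 1.5-fold (0.17 log units) apart, within the scatter of two such steps. Methoxy in place of methyl on an aromatic carbon gives a 1.2-fold higher number from compound 2 to compound 4 (0.08 log units; within the scatter), which extends that change to the 2-chlorophenyl compounds: the same change on two cores in this assay, a 1.8-fold higher number (0.25 log units; within the scatter) from compound 1 to compound 3 and a 1.2-fold higher number (0.08 log units; within the scatter) from compound 2 to compound 4, 1.5-fold (0.17 log units) apart, within the scatter of two such steps.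

All four steps stay within the scatter, so neither place has yet shown a clear effect on the number. On these data alone, whether a carboxylic acid or an amine at either place would give a step beyond the scatter remains open.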